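The source may report more compounds than this note shows. Statements on the series, on what has been measured and on what is new or still open speak of the compounds shown alone.

Compound 1 `O=C(/C=C/c1ccc2c(c1)B(O)OC2)c1ccc(I)cc1`, compound 2 `COc1cccc(C(=O)/C=C/c2ccc3c(c2)B(O)OC3)c1` and compound 3 `O=C(/C=C/c1ccc2c(c1)B(O)OC2)c1ccc(F)cc1` were tested in an ADME assay on L929 cells (Mus musculus) for cytotoxicity, read by resazurin assay, with a stated time of 72 h; a lower number here means a stronger inhibitor, a higher number a weaker inhibitor. In this assay compound 1 gives > 10 ug/mL, a limit of the assay rather than a number. Compound 2 gives > 10 ug/mL, again a limit. Compound 3 gives > 10 ug/mL, also a limit. Among the measured compounds shown here, compound 3 therefore stands at the limit shared by every value measured so far (the limit of > 10 ug/mL in this assay, at which 3 of the 3 values shown sit). For the measured compounds named here, the one step between measured compounds, a step that the two limits leave unreadable from compound 1 to compound 3, cannot be read; both its ends are limits. Compound 4 `O=C(/C=C/c1ccc2c(c1)B(O)OC2)c1cccc(O)c1` differs from compound 3 by 3-hydroxyphenyl in place of 4-fluorophenyl on a carbonyl carbon. Going by the values given here, no measured step bears on this change, so nothing beyond the scatter is expected in this assay, and compound 4 is expected to remain at the limit. The estimate for compound 4 is 20 ug/mL, with a range from 8 ug/mL to 60 ug/mL. The step this estimate means, a step that the limit leaves unreadable from compound 3 to compound 4, is expected to lie within the scatter.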

Compound 4, half-maximal inhibitory concentration: 7.56 ug/mL
Compound 4: middle estimate off by 2.6-fold (0.42 log units), on the high side, outside the stated range (below it).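

In this assay compound 4 is the first compound shown to give a number rather than a limit: the limit of > 10 ug/mL in this assay, at which 3 of the 4 values shown sit. Placing 3-hydroxyphenyl on the carbonyl carbon gives an at least 1.3-fold lower number from compound 3 to compound 4 (0.12 log units; that floor lies within the scatter) and an at least 1.3-fold lower number from compound 1 to compound 4 (0.12 log units; that floor lies within the scatter), while hydrogen in place of methyl on the oxygen gives an at least 1.3-fold lower number from compound 2 to compound 4 (0.12 log units; that floor lies within the scatter). Each of these steps is only a floor, so none yet shows a change beyond the scatter, and the step between the two limits cannot be read.

As far as these compounds go, the true size of these steps stays open. So does what an amine or a carboxylic acid in place of the hydroxyl would give in this assay.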